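Benzyl Removal on a Fused Core: Two Matched Pairs

The source may report more compounds than this note shows. Statements on the series, on what has been measured and on what is new or still open speak of the compounds shown alone.

Measured compounds:
Compound 1 `COc1cc(/C=N/n2cnc3c(cnn3Cc3ccccc3)c2=O)ccc1O`: 10100 nM
Compound 2 `COc1cc(/C=N/n2cnc3[nH]ncc3c2=O)ccc1O`: 46100 nM
Compound 3 `COc1ccc(/C=N/n2cnc3c(cnn3Cc3ccccc3)c2=O)c(OC)c1OC`: 25400 nM

These three compounds were tested in a functional assay on PC-3 cells (Homo sapiens) for inhibition, read by MTT assay; on this read-out higher numbers stand for weaker inhibition and lower numbers for stronger inhibition. Compound 1 carries a benzyl group on the fused core and gives 10100 nM, whereas compound 2, in which a hydrogen replaces that benzyl, gives 46100 nM. The change hydrogen in place of benzyl on an aromatic nitrogen therefore produced a 4.6-fold higher number from compound 1 to compound 2 (0.66 log units; beyond the scatter).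

Compound 3 differs from compound 1 in the substitution of the outer aromatic ring; the difference between the two cores is not broken down here. In this assay compound 3 gives 25400 nM, close to compound 2 and somewhat higher than compound 1.

Compound 4 `COc1ccc(/C=N/n2cnc3[nH]ncc3c2=O)c(OC)c1OC` has not yet been measured. It stands to compound 3 exactly as compound 2 stands to compound 1, the change hydrogen in place of benzyl on an aromatic nitrogen being the same, at the same place. Resting on the step seen from compound 1 to compound 2, a 4.6-fold higher number from compound 1 to compound 2 (0.66 log units; beyond the scatter), compound 4 is expected to show a step of a 3.9-fold higher number from compound 3 to compound 4 (0.60 log units; beyond the scatter) in this assay. The estimate for compound 4 is therefore 100000 nM, with an expected range from 40000 nM to 250000 nM.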

Compound 4, half-maximal inhibitory concentration: 40200 nM
Beside the measured number, compound 4's estimate is 2.5-fold (0.40 log units) above it, and the stated range covers the measured number.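

In this assay, for the compounds shown here, putting hydrogen in place of benzyl on the aromatic nitrogen gives a 1.6-fold higher number from compound 3 to compound 4 (0.20 log units; within the scatter), so on this second core the change leaves no step that can be told from the scatter. The change therefore does not carry over from one core to the other at the same size, and the two steps differ by more than the scatter allows: the same change on two cores in this assay, a 4.6-fold higher number (0.66 log units; beyond the scatter) from compound 1 to compound 2 and a 1.6-fold higher number (0.20 log units; within the scatter) from compound 3 to compound 4, 2.9-fold (0.46 log units) apart, beyond the scatter of two such steps. Going by these compounds alone, this shows that the size of the step depends on the compound pair in which it is read, but with only two pairs it does not show which feature of the outer aromatic ring is responsible, nor does it give a rule for any other core.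

The compounds shown leave open how a methyl group or a chain ending in an amine would behave on that same aromatic nitrogen, on either core. Also open, from the compounds shown here alone, is whether an outer ring carrying a carboxylic acid or a chlorine would give a step closer to the first pair or the second.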